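Swapping the aryl end of the enone on the shared core

The compounds below may be only part of what the source reports. "The series", "measured", "known", "first", "only" and "open" are said of these compounds alone.

The series shares one core, varied only at the aryl group on the enone arm. Compound 1 `COc1cccc(COc2ccc3cc(C(=O)/C=C/c4cccc(OC)c4OC)c(=O)oc3c2)c1` gives 22800 nM in a functional assay on MOLT-4 cells (Homo sapiens) for cytotoxicity, read by MTT assay, with a stated time of 72 h; a lower number here means a stronger inhibitor, a higher number a weaker inhibitor. Compound 2 `COc1cccc(COc2ccc3cc(C(=O)/C=C/c4cc(OC)ccc4OC)c(=O)oc3c2)c1` gives 13800 nM in this assay; the step of a 1.7-fold lower number from compound 1 to compound 2 (0.22 log units; within the scatter) lies within the scatter. Compound 3 `COc1cccc(COc2ccc3cc(C(=O)/C=C/c4ccc(Cl)cc4Cl)c(=O)oc3c2)c1` gives "not determined" (no result reported) in this assay, so it stands nowhere on the values shown and offers no anchor of its own. Compound 4 `COc1ccc(/C=C/C(=O)c2cc3ccc(OCc4cccc(OC)c4)cc3oc2=O)cc1` differs from compound 3 by 4-methoxyphenyl in place of 2,4-dichlorophenyl on a double-bonded chain carbon bound to a double-bonded chain carbon. Within the data shown here, no measured step bears directly on this change; the only step in hand, from compound 1 to compound 2, moves methoxy groups around the same ring and is within the scatter, so the change from a methoxy-substituted ring to another methoxy-substituted ring gave no shift beyond noise. Compounds 1 and 2 therefore set the range where an aryl group with one methoxy group is expected to fall. Compound 4 is expected to give about 16000 nM, estimated between 5000 nM and 50000 nM.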

Compound 4, half-maximal inhibitory concentration: > 100000 nM
Compound 4 gave a limit, no number (the forecaster's own chance of this, stated with the estimate: 20%); middle value at least 6.2-fold (0.79 log units) away from the limit.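

Compound 4 gave a limit and not a number in this assay: the limit of > 100000 nM in this assay, at which 1 of the 4 values shown sits.

The earlier pair showed nothing beyond the scatter when the methoxy groups moved around the ring, but this position does respond to the choice of aryl group. Replacing either dimethoxyphenyl group with 4-methoxyphenyl gives an at least 7.2-fold higher number from compound 2 to compound 4 (0.86 log units; beyond the scatter) and an at least 4.3-fold higher number from compound 1 to compound 4 (0.64 log units; beyond the scatter), so in this series 4-methoxyphenyl does not serve as an equal of 2,5-dimethoxyphenyl or 2,3-dimethoxyphenyl.

Compound 3 has no result, so the change from 2,4-dichlorophenyl to 4-methoxyphenyl cannot be read. From the compounds shown here alone, it also remains open whether a phenyl ring carrying a hydroxy group or a dimethylamino group in place of the methoxy group would stay at such a limit or return to the range of compound 1 and compound 2.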